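The compounds below may be only part of what the source reports. "The series", "measured", "known", "first", "only" and "open" are said of these compounds alone.

Measured compounds in an in vitro functional assay on chem-1 cells for antagonist activity at lysophosphatidic acid receptor 3 (Homo sapiens), read by FLIPR and calcium flux, with stated times of 30 min and 100 s; on this read-out lower numbers stand for stronger inhibition and higher numbers for weaker inhibition:
Compound 1 `COc1ccc(-c2cnn(C)c2NC(=O)O[C@H](C)c2ccccc2)cc1` — compound 1 gives > 30000 nM, a limit of the assay.
Compound 2 `C[C@@H](OC(=O)Nc1c(-c2ccc(CC(=O)O)cc2)cnn1C)c1ccccc1` — compound 2 gives > 30000 nM, a limit of the assay.
Compound 3 `C[C@@H](OC(=O)Nc1c(-c2ccc(-c3ccc(CC(=O)O)cc3)cc2)cnn1C)c1ccccc1` — compound 3 gives > 30000 nM, a limit of the assay.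

Compound 3 therefore stands at the limit of > 30000 nM in this assay, at which 3 of the 3 values shown sit, as do the two other measured compounds. Compound 4 `C[C@@H](OC(=O)Nc1c(-c2ccc(-c3ccc(C4(C(=O)O)CC4)cc3)cc2)cnn1C)c1ccccc1` differs from compound 3 by 1-carboxycyclopropyl in place of carboxymethyl on an aromatic carbon. The steps a step that the two limits leave unreadable from compound 1 to compound 3 and a step that the two limits leave unreadable from compound 2 to compound 3 bear on the carboxymethylphenyl end, but both are unreadable because each end sits at the limit of > 30000 nM in this assay, at which 3 of the 3 values shown sit; the same holds for a step that the two limits leave unreadable from compound 1 to compound 2. No readable step exists, so no direction of change is supported. Compound 4 is therefore expected to give 30000 nM (range 10000 nM to 100000 nM) in this assay, most likely again as a limit. The step of a number no higher from compound 3 to compound 4 (the limit leaves the size open) is thus estimated as none beyond the scatter.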

Compound 4, half-maximal inhibitory concentration: 8340 nM
Compound 4: middle estimate off by 3.6-fold (0.56 log units), on the high side, and the stated range ends above it.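

In this assay, within the data shown here, the change to 1-carboxycyclopropyl gives the first readable step, an at least 3.5-fold lower number from compound 3 to compound 4 (0.55 log units; beyond the scatter), showing that the group at this aromatic carbon can move the read-out. Among these compounds, the steps of an at least 3.5-fold lower number from compound 2 to compound 4 (0.55 log units; beyond the scatter) and an at least 3.5-fold lower number from compound 1 to compound 4 (0.55 log units; beyond the scatter) are also readable, while those among the earlier compounds cannot be read. The full size of all three new steps stays open because their starting values are limits: the limit of > 30000 nM in this assay, at which 3 of the 4 values shown sit.

Going by these compounds, it remains open whether the three-membered ring itself matters, or whether a 1-carboxycyclobutyl group would serve equally. On these data alone, it is also open whether an amide could replace the carboxylic acid.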